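This account rests on a few compounds, and the source may have more. Where it says the series, first, only, none or still open, it means among the compounds named here.

Working notes on the series in a functional assay on BXPC-3 cells (Homo sapiens) for inhibition, read by MTT assay, with a stated time of 7 days; a lower number here means a stronger inhibitor, a higher number a weaker inhibitor. Compound 1 `CCN(CC)S(=O)(=O)c1ccc(S(=O)(=O)N2CCC[C@@H](C(=O)N(C)C(C)C)C2)cc1` gives 7700 nM in this assay. Compound 2 `CCOC(=O)C1CCN(S(=O)(=O)c2ccc(S(=O)(=O)N(CC)CC)cc2)CC1` gives 23100 nM in this assay. For compound 3 `CCOC(=O)[C@@H]1CCCN(S(=O)(=O)c2ccc(S(=O)(=O)N(C)Cc3ccccc3)cc2)C1` this assay reports only a limit, > 30000 nM, so compound 3 stands at the limit rather than at a number, as shown by the limit of > 30000 nM in this assay, at which 1 of the 3 values shown sits. The change to compound 4 `CCOC(=O)[C@@H]1CCCN(S(=O)(=O)c2ccc(S(=O)(=O)N(C)C)cc2)C1` is hydrogen in place of phenyl on a saturated chain carbon bound to a sulfonamide nitrogen. No step between measured compounds covers this change, and compound 3 itself is a limit, so the direction cannot be read from the data shown. Compound 4 is expected to remain weak, with the step of a number no higher from compound 3 to compound 4 (the limit leaves the size open) estimated as none beyond the scatter. The estimate for compound 4 is 30000 nM, ranging from 10000 nM to 100000 nM.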

Compound 4, half-maximal inhibitory concentration: 1000 nM
Beside the measured number, compound 4's estimate is 30-fold (1.48 log units) above it; the measured number lies below the stated range.
By their numbers in this assay, from the lowest: compound 4; then compound 1; then compound 2. At a limit, above all of these: compound 3.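

In this assay, benzyl(methyl)amino to dimethylamino gives an at least 30-fold lower number from compound 3 to compound 4 (1.47 log units; beyond the scatter). Among the compounds shown here, this is the first reading at this position, and it shows that the phenyl is not required for a measurable number here, with the smaller dimethylamino group on the better side. Compound 3 stands at a limit, so the size of this step stays open on one side: the limit of > 30000 nM in this assay, at which 1 of the 4 values shown sits.

From the compounds shown here alone, whether a longer chain or a chain ending in an amine in place of the benzyl would hold the number of compound 4 stays open. So does whether the change carries over to the amide of compound 1.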